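The compounds below may be only part of what the source reports. "The series", "measured", "known", "first", "only" and "open" are said of these compounds alone.

Compound 1 `COc1ccc(-c2cnc(NC(=O)C3CCNCC3)n2C)cc1` is the reference point of this note. In a toxicity assay on THP-1 cells (Homo sapiens) for inhibition (on this read-out lower numbers stand for higher toxicity in this test and higher numbers for lower toxicity in this test), compound 1 gives > 100000 nM, which is a limit of the test rather than a number. Compound 2 `Cn1c(-c2cccc([N+](=O)[O-])c2)cnc1NC(=O)c1ccc(F)cc1` is the second measured member. In this assay compound 2 gives > 50000 nM, again only a limit. For the measured compounds named here, both results sit at limits, the limit of > 100000 nM in this assay, at which 1 of the 2 values shown sits, and (the limit of > 50000 nM in this assay, at which 1 of the 2 values shown sits), so no measured step can be sized. Compound 3 `COc1ccc(-c2cnc(NC(=O)c3cccc(O)c3)n2C)cc1` differs from compound 1 by 3-hydroxyphenyl in place of piperidin-4-yl on a carbonyl carbon. The change is expected to give no step beyond the scatter, a number no higher from compound 1 to compound 3 (the limit leaves the size open). Compound 3 is estimated at 100000 nM, expected between 30000 nM and 200000 nM.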

Compound 3, half-maximal cytotoxic concentration: > 100000 nM
Compound 3: only a limit was reported; the forecaster's own chance of this, stated with the estimate: 70%; the middle value sits exactly at the limit.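

In this assay compound 3 gives > 100000 nM, which is a limit. For the compounds shown here, compound 1 also sits at a limit, and no step between compound 1 and compound 3 can be read. The compounds shown leave open what half-maximal cytotoxic concentration any of them actually has.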